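This account rests on a few compounds, and the source may have more. Where it says the series, first, only, none or still open, it means among the compounds named here.

Measured compounds in a functional assay on HeLa cells (Homo sapiens) for antiproliferative activity, read by MTT assay, with a stated time of 72 h; a lower number here means a stronger inhibitor, a higher number a weaker inhibitor:
compound 1, `CCN(CC)C(=S)SCC1=CC(=O)OC1` — 21000 nM
compound 2, `O=C1OCC=C1CSC(=S)NC1CC1` — 24100 nM
compound 3, `O=C1OCC=C1CSC(=S)Nc1ccc(Cl)cc1` — "not active" (no number reported)

For the measured compounds named here, compound 2 and compound 1 are the only two members with a number in this assay, and their values lie within the usual scatter of each other, so neither can be placed ahead of the other. Compound 3 carries no number in this assay and is reported only as not active; it offers no scale for comparison with compound 2.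

Compound 4, `CC(C)NC(=S)SCC1=CCOC1=O`, is not yet measured. Relative to compound 2 the change is isopropyl in place of cyclopropyl on an amide-type nitrogen. Going by the values given here, no step between measured compounds involves a change of this kind, so there is no measured precedent to lean on. With two measured numbers sitting within the scatter of each other and the third compound without a number, the expectation for this assay is a step from compound 2 to compound 4 of no size beyond the scatter, in no preferred direction, estimated as a 1.0-fold higher number from compound 2 to compound 4 (0.02 log units; within the scatter). Compound 4 is accordingly expected to give about 25000 nM in this assay, with a range from 10000 nM to 60000 nM.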

Compound 4, half-maximal inhibitory concentration: 137000 nM
Beside the measured number, compound 4's estimate is 5.5-fold (0.74 log units) below it, outside the stated range (above it).
By their numbers in this assay, from the lowest: compounds 1 and 2 (each within the scatter of the next); then compound 4.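

In this assay, for the compounds shown here, isopropyl in place of cyclopropyl on an amide-type nitrogen gives a 5.7-fold higher number from compound 2 to compound 4 (0.75 log units; beyond the scatter) and is the only step read so far, so this nitrogen substituent is not indifferent to the change. The two groups have the same count of heavy atoms, all carbon, and what differs in the computed description is the three-membered ring that leaves with cyclopropyl, although a single step cannot show that the ring itself is what matters. No measurement at hand bears on the reason for this step.

From the compounds shown here alone, it remains open whether a cyclobutyl or cyclopentyl ring, or a straight propyl chain, on the same nitrogen would stand with compound 2 or with compound 4 in this assay. Going by these compounds, the step also rests on one pair, so its size on any other core remains unknown.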